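Methoxy in place of methyl on the shared core

The source may report more compounds than this note shows. Statements on the series, on what has been measured and on what is new or still open speak of the compounds shown alone.

In a functional assay on MCF7 cells (Homo sapiens) for antiproliferative activity, read by MTT assay, with a stated time of 48 h (on this read-out higher numbers stand for weaker inhibition and lower numbers for stronger inhibition), compound 3 (`Cc1ccc2[nH]c(-c3cn(-c4ccccc4)nc3-c3ccccc3)nc2c1`) gives the highest of three numbers at 5940 nM in this series, ahead of compound 1 (`Fc1ccc2[nH]c(-c3cn(-c4ccccc4)nc3-c3ccccc3)nc2c1`) at 2430 nM and compound 2 (`Brc1ccc2[nH]c(-c3cn(-c4ccccc4)nc3-c3ccccc3)nc2c1`) at 830 nM on the same read-out. The next compound, compound 4 (`COc1ccc2[nH]c(-c3cn(-c4ccccc4)nc3-c3ccccc3)nc2c1`), carries methoxy in place of methyl on an aromatic carbon and is otherwise unchanged. Going by the values given here, no measured compound carries methoxy, so the evidence is indirect. At this same place the data show a 2.4-fold higher number from compound 1 to compound 3 (0.39 log units; beyond the scatter) and a 7.2-fold higher number from compound 2 to compound 3 (0.85 log units; beyond the scatter) in this assay as the two steps ending at methyl, along with a 2.9-fold lower number from compound 1 to compound 2 (0.47 log units; beyond the scatter) between the other two groups. All three steps are modest, and compound 3 already holds the highest number, so only a small move towards a lower number is expected, probably none beyond the scatter. The expected change is a 1.5-fold lower number from compound 3 to compound 4 (0.17 log units; within the scatter) on this estimate. The estimated value for compound 4 is 4000 nM within an expected range of 1500 nM to 10000 nM on this read-out.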

Compound 4, half-maximal inhibitory concentration: 1590 nM
Beside the measured number, compound 4's estimate is 2.5-fold (0.40 log units) above it, and the stated range covers the measured number.
By their numbers in this assay, from the lowest: compounds 2, 4 and 1 (each within the scatter of the next, the first and the last beyond it); then compound 3.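

In this assay, replacing methyl with methoxy gives a 3.7-fold lower number from compound 3 to compound 4 (0.57 log units; beyond the scatter) and so shows that a change at this position, on an aromatic carbon of the shared core, can move the number beyond the scatter without a halogen being present. Methoxy cannot be separated from either halogen, with a 1.9-fold higher number from compound 2 to compound 4 (0.28 log units; within the scatter) on the change from bromo and a 1.5-fold lower number from compound 1 to compound 4 (0.18 log units; within the scatter) on the change from fluoro, even though compound 1 and compound 2 differ beyond the scatter. Among these four compounds, compound 3 is thus the only one whose steps to all the others lie beyond the scatter.

On these data alone, whether an amine, a hydroxyl or a longer chain such as ethoxy at this position would fall with compound 4 or with compound 3 remains open. Nothing given here explains the effect of methoxy at this position.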